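The source may report more compounds than this note shows. Statements on the series, on what has been measured and on what is new or still open speak of the compounds shown alone.

Three compounds have been measured in an assay on T-REx-293 cells for inhibition of potassium channel subfamily T member 1 (Homo sapiens), read by patch clamp; a higher number here means a weaker inhibitor, a lower number a stronger inhibitor:
compound 1 `Cc1ccnc(-c2noc([C@H](C)NC(=O)c3cc(C(F)(F)F)nn3C)n2)c1` gives 4470 nM;
compound 2 `Cc1cc(-c2noc([C@H](C)NC(=O)c3cc(C(F)(F)F)nn3C)n2)ccn1` gives 165 nM;
compound 3 `C[C@H](NC(=O)c1cc(C(F)(F)F)nn1C)c1nc(-c2ccccn2)no1` gives > 30000 nM.

For compound 3 that figure is only a limit of this assay, not a measured number, so compound 3 stands at the weak end of the three. Compound 4 `C[C@H](NC(=O)c1cc(C(F)(F)F)nn1C)c1nc(-c2ccncc2)no1` differs from compound 3 by pyridin-4-yl in place of pyridin-2-yl on an aromatic carbon. The closest measured step is a 27-fold lower number from compound 1 to compound 2 (1.43 log units; beyond the scatter), which is the same kind of exchange carried out with a methyl on the ring, and an at least 180-fold higher number from compound 2 to compound 3 (2.25 log units; beyond the scatter) points the same way. A large fall in the number is therefore expected. Compound 4 is estimated at 2500 nM, within 600 nM to 12000 nM, an expected step of an at least 12-fold lower number from compound 3 to compound 4 (1.07 log units; beyond the scatter).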

Compound 4, half-maximal inhibitory concentration: 5250 nM
The estimate for compound 4 lay 2.1-fold (0.32 log units) below the measured number; the measured number falls inside the stated range.
By their numbers in this assay, from the lowest: compound 2; then compounds 1 and 4 (each within the scatter of the next). At a limit, above all of these: compound 3.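

Even without a methyl, the place of the ring nitrogen matters: pyridin-4-yl in place of pyridin-2-yl gives an at least 5.7-fold lower number from compound 3 to compound 4 (0.75 log units; beyond the scatter), a step that rests on a limit rather than a measured number. On the pyridin-4-yl ring, hydrogen in place of methyl gives a 32-fold higher number from compound 2 to compound 4 (1.50 log units; beyond the scatter), so much of the strength of compound 2 goes with its methyl. A methyl on the pyridin-2-yl ring and a change to unsubstituted pyridin-4-yl end up alike, with a 1.2-fold higher number from compound 1 to compound 4 (0.07 log units; within the scatter).

On these data alone, it remains open how pyridin-3-yl would compare. Also open, as far as these compounds go, is whether an ethyl or a methoxy on the pyridin-4-yl ring would lower the number further.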